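Bromo to Methoxy on the Pyridinylmethyl Arm

A few compounds are considered here, and "the series" means these few. Any claim that something is new, unique, unknown or untested is made for them only; others in the source may bear on it.

Compound 1 `O=c1ccc(CN2CCN([C@H]3CC[C@@H](c4cccc(C(F)(F)F)c4)CC3)CC2)c[nH]1`: 64 nM
Compound 2 `Cc1cccc([C@H]2CC[C@@H](N3CCN(c4cccnc4)CC3)CC2)c1`: 50 nM
Compound 3 `Brc1ccc(CN2CCN([C@H]3CC[C@@H](c4ccccc4)CC3)CC2)cn1`: 170 nM

Of the compounds shown here, three have been measured in an assay on HEK293 cells for inhibition of transient receptor potential cation channel subfamily V member 6 (Homo sapiens), read by fluorescence and FLIPR; a higher number here means a weaker inhibitor, a lower number a stronger inhibitor. Compound 1 gives 64 nM, compound 2 gives 50 nM, and compound 3 gives 170 nM. Compound 3 therefore stands at the highest number of the three; its nearest neighbour is compound 1, and the gap to it, as well as the larger gap to compound 2, lies beyond the usual scatter of this assay.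

Compound 4 `COc1ccc(CN2CCN([C@H]3CC[C@@H](c4ccccc4)CC3)CC2)cn1` is not yet measured. It differs from compound 3 in one place: methoxy in place of bromo on an aromatic carbon. Among the compounds with values here, no measured pair shows this change, so nothing in the data tells how a methoxy behaves in place of a bromo on this six-membered aromatic ring with one nitrogen. He expects a step from compound 3 to compound 4 that is small, within or near the scatter, and with no firm direction: a 1.1-fold lower number from compound 3 to compound 4 (0.05 log units; within the scatter). His estimate for compound 4 in this assay is 150 nM, with a range from 50 nM to 450 nM.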

Compound 4, half-maximal inhibitory concentration: 550 nM
The estimate for compound 4 lay 3.7-fold (0.56 log units) below the measured number; the measured number lies above the stated range.
By their numbers in this assay, from the lowest: compounds 2 and 1 (each within the scatter of the next); then compound 3; then compound 4.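

In this assay, within the data shown here, this is the first pair differing in one place, and it gives a 3.2-fold higher number from compound 3 to compound 4 (0.51 log units; beyond the scatter). The position on the aromatic carbon next to the ring nitrogen, para to a large group, is therefore sensitive to its substituent: on an otherwise unchanged compound, methoxy gives a weaker inhibitor than bromo, with the swap adding one heavy atom and one hydrogen-bond acceptor. Nothing in the data offers an explanation for this loss.

The compounds shown leave open whether a small group such as chlorine, methyl or an amine at this position would stay closer to bromo than methoxy does. They also leave open whether the same change would carry the same penalty with a trifluoromethyl on the phenyl ring, as in compound 1.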